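A few compounds are considered here, and "the series" means these few. Any claim that something is new, unique, unknown or untested is made for them only; others in the source may bear on it.

Compound 1 `C=C1C(=O)OC[C@H]1CCOC(=O)Nc1ccccc1` gives 390 nM in a functional assay on RAW264.7 cells (Mus musculus) for inhibition, with a stated time of 30 min; a higher number here means a weaker inhibitor, a lower number a stronger inhibitor.
Compound 2 `C=C1C(=O)OC[C@H]1CCOC(=O)Nc1ccc(C(C)C)cc1` gives 340 nM in this assay.

For the measured compounds named here, compound 2 shows the lower of the two numbers in this assay, but the only measured step, a 1.1-fold lower number from compound 1 to compound 2 (0.06 log units; within the scatter), lies within the scatter, so the two compounds cannot be told apart on these data. Compound 3 `C=C1C(=O)OC[C@H]1CCOC(=O)Nc1ccc(CC)cc1` differs from compound 2 by hydrogen in place of methyl on a saturated chain carbon bound to an aromatic carbon and a saturated chain carbon. Going by the values given here, the one step that bears on this change is the one from compound 1 to compound 2, which put an isopropyl group onto the aromatic carbon that compound 1 carries as hydrogen; that step was within the scatter. Shortening the isopropyl to ethyl is a smaller change at the same place, so no step beyond the scatter is expected in this assay. Compound 3 is therefore estimated at 360 nM, with a range from 180 nM to 720 nM. That estimate means an expected step of a 1.1-fold higher number from compound 2 to compound 3 (0.02 log units; within the scatter).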

Compound 3, half-maximal inhibitory concentration: 840 nM
Estimate against measurement, compound 3: 2.3-fold (0.37 log units) below, outside the stated range (above it).
By their numbers in this assay, from the lowest: compounds 2 and 1 (each within the scatter of the next); then compound 3.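

Shortening isopropyl to ethyl matters in this assay: the change gives a 2.5-fold higher number from compound 2 to compound 3 (0.39 log units; beyond the scatter) and so shows that the group on this aromatic carbon can shift the number, which the earlier pair of compounds did not reveal. Ethyl in place of hydrogen on the same carbon likewise gives a 2.2-fold higher number from compound 1 to compound 3 (0.33 log units; beyond the scatter) even though isopropyl in that place stayed within the scatter of hydrogen, so among these three compounds the number does not move in one direction as carbons are added. The data at hand offer no explanation for this behaviour.

As far as these compounds go, whether a methyl or a methoxy group on this carbon would resemble compound 3 or the pair of compound 1 and compound 2 remains open. Also open, from the compounds shown here alone, is whether a longer chain, such as propyl or butyl, would give a number like that of the ethyl compound.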